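Compound 2 to compound 4: dichloropyridinyl replaces dichlorophenyl

The source may hold more compounds than are shown below. What is called first, only, known or untested is meant among the compounds shown, and "the series" means these compounds.

Compound 2 `N#Cc1cnc(NC(=O)N2CCN(c3ccc(Cl)c(Cl)c3)CC2)s1` stands lowest of the three numbers in an ADME assay on microsomes from liver (Mus musculus) for metabolic stability, read by LC-MS, with a stated time of 60 min, tested at 1 uM (on this read-out lower numbers stand for slow clearance and higher numbers for fast clearance), where compound 2 gives 15 mL.min-1.g-1. Compound 3 `Cc1ccc(N2CCN(C(=O)Nc3ncc(Cl)s3)CC2)cc1Cl` gives 53 mL.min-1.g-1 and compound 1 `Cc1cnc2[nH]c(N3CCN(c4ccc(C)c(Cl)c4)CC3)nc2c1` gives 224 mL.min-1.g-1; both of these gaps to compound 2 lie beyond the scatter. Compound 4 `N#Cc1cnc(NC(=O)N2CCN(c3cnc(Cl)c(Cl)c3)CC2)s1` has not yet been run. The change from compound 2 is 5,6-dichloropyridin-3-yl in place of 3,4-dichlorophenyl on an amine nitrogen in a ring. For the measured compounds named here, no measured pair in the set shares this change, so there is no step to lean on; the only guide is the value of compound 2 itself. The expectation for compound 4 in this assay is a step of a 1.3-fold lower number from compound 2 to compound 4 (0.10 log units; within the scatter), small and likely within the scatter. Compound 4 is estimated at 12 mL.min-1.g-1, with a range from 5 mL.min-1.g-1 to 30 mL.min-1.g-1.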

Compound 4, intrinsic clearance in microsomes in the Mus musculus assay: 22 mL.min-1.g-1
Compound 4: middle estimate off by 1.8-fold (0.26 log units), on the low side, within the range that was stated.
By their numbers in the Mus musculus assay, from the lowest: compounds 2 and 4 (each within the scatter of the next); then compound 3; then compound 1.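

In the Mus musculus assay the change to 5,6-dichloropyridin-3-yl from 3,4-dichlorophenyl gives a 1.5-fold higher number from compound 2 to compound 4 (0.17 log units; within the scatter) and so, on an amine nitrogen in a ring, the two aromatic rings stand level on this read-out. In a physicochemical assay for solubility, read by nephelometry, at pH 6.5 (on this read-out lower numbers stand for lower solubility and higher numbers for higher solubility), compound 2 gives < 1600 nM as a limit of the assay and not a number. In the physicochemical assay compound 4 gives < 1600 nM as a limit too.

The step between these two cannot be read because both sit at the same limit: the limit of < 1600 nM in the physicochemical assay, at which 2 of the 2 values shown sit. As far as these compounds go, whether an amine or a carboxylic acid on this aromatic ring would bring a readable number in the physicochemical assay stays open.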